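The compounds below may be only part of what the source reports. "The series", "measured", "known", "first", "only" and "open" are said of these compounds alone.

Three amides built on one shared core have been examined in a functional assay on HeLa cells (Homo sapiens) for antiproliferative activity, read by sulforhodamine B assay, with a stated time of 48 h; on this read-out higher numbers stand for weaker inhibition and lower numbers for stronger inhibition. Compound 1 `COc1ccc(C[C@@H](O)/C=C/C=C/C(=O)N2CCCCC2)cc1OC` carries a piperidin-1-yl on the carbonyl carbon and gives 14100 nM. Compound 2 `COc1ccc(C[C@@H](O)/C=C/C=C/C(=O)NCc2ccc(Cl)cc2)cc1OC`, with (4-chlorobenzyl)amino in that place, gives 13400 nM, and compound 3 `COc1ccc(C[C@@H](O)/C=C/C=C/C(=O)N2CCN(c3ccccc3)CC2)cc1OC` gives 9750 nM. Compound 1 shows the highest number of the three, yet its nearest neighbour compound 2 and its furthest neighbour compound 3 both sit within the scatter of it, so the three cannot be told apart. Going by the values given here, the one measured step that matters here, a 1.1-fold lower number from compound 1 to compound 2 (0.02 log units; within the scatter), shows that replacing the piperidin-1-yl by a substituted benzylamine left the number essentially unchanged. Compound 4 `COc1ccc(C[C@@H](O)/C=C/C=C/C(=O)NCc2ccccc2)cc1OC` differs from compound 1 as follows: benzylamino in place of piperidin-1-yl on a carbonyl carbon. Among the compounds with values here, this change closely resembles the step from compound 1 to compound 2, differing only by the chloro substituent, and compound 2 is the sole measured compound that bears on it. Because that step stayed within the scatter, the step of a 1.1-fold lower number from compound 1 to compound 4 (0.04 log units; within the scatter) is expected to be small, in no particular direction. Compound 4 is therefore estimated at 13000 nM, within a range from 6000 nM to 28000 nM.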

Compound 4, half-maximal inhibitory concentration: 12900 nM
Compound 4: the middle estimate sits 1.0-fold (0.00 log units) above what was measured; measured number inside the range.
By their numbers in this assay, from the lowest: compounds 3, 4, 2 and 1 (each within the scatter of the next).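

Hydrogen in place of chloro on an aromatic carbon gives a 1.0-fold lower number from compound 2 to compound 4 (0.02 log units; within the scatter) in this assay, so this pair shows that the chloro substituent makes no readable difference here. The step of a 1.1-fold lower number from compound 1 to compound 4 (0.04 log units; within the scatter) shows the same for the bare benzylamino group, which carries a hydrogen-bond donor and an aromatic ring, and the piperidin-1-yl, which carries neither, on this carbonyl carbon. Nothing at hand accounts for this lack of a readable difference.

From the compounds shown here alone, it remains open whether a carboxylic acid or a dimethylamino group in place of chloro on an aromatic carbon, or a phenethylamino group in place of benzylamino on the carbonyl carbon, would give a step beyond the scatter. Going by these compounds, it is also open whether replacing the hydroxyl group of the shared core with a methoxy group would do so.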